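The source may hold more compounds than are shown below. What is called first, only, known or untested is meant among the compounds shown, and "the series" means these compounds.

Measured so far:
Compound 1 `CC1CCC(C(=O)N2CC(c3nc(-c4cccc(Cl)c4)no3)C2)CC1`: 1500 nM
Compound 2 `O=C(c1ccc(F)c(F)c1)N1CC(c2nc(-c3cccc(F)c3)no2)C1`: 3200 nM

Both numbers come from an assay on HEK293 cells for positive allosteric modulation of metabotropic glutamate receptor 5 (Homo sapiens), read by FLIPR; a lower number here means that less compound is needed, a higher number that more compound is needed for the effect. Compound 1 has the lowest of the two numbers; compound 2 sits a step above it that is beyond the usual scatter of repeat measurements. The two compounds differ in two places at once, so the gap between them cannot be tied to either change alone.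

Compound 3 `O=C(c1cccc(F)c1)N1CC(c2nc(-c3cccc(Cl)c3)no2)C1` has not yet been measured. It differs from compound 1 in one place only: 3-fluorophenyl in place of 4-methylcyclohexyl on a carbonyl carbon. For the measured compounds named here, compound 2 also carries an aromatic ring on that carbonyl carbon, and in this assay compound 2 shows the higher of the two numbers, but compound 2 also differs from compound 1 in the group on its other ring, so no step from this change alone is known. On that basis a modest rise is expected, a 1.5-fold higher number from compound 1 to compound 3 (0.17 log units; within the scatter), with little certainty that it will reach beyond the scatter. Compound 3 is therefore expected to give about 2200 nM in this assay, within a range from 800 nM to 6000 nM.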

Compound 3, half-maximal effective concentration: > 10000 nM
Compound 3 was reported as a limit; the forecaster's own chance of this, stated with the estimate: 5%; at least 4.5-fold (0.65 log units) between middle value and limit.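

For the compounds shown here, changing only the group on the carbonyl carbon gives the first clean reading of this position in this assay: replacing 4-methylcyclohexyl with 3-fluorophenyl gives an at least 6.6-fold higher number from compound 1 to compound 3 (0.82 log units; beyond the scatter). Going by these compounds, compound 3 reads > 10000 nM, which is a limit and not a number, so the full size of this step stays unknown: the limit of > 10000 nM in this assay, at which 1 of the 3 values shown sits. The two groups match in heavy-atom count, in having no hydrogen-bond donors or acceptors and in carrying no net charge, yet they are far from interchangeable here, which shows that such matching counts say little about how a group will behave at this position.

The compounds shown do not tell whether this step goes with the aromatic ring itself, with its fluorine, or with the loss of the methyl group on the non-aromatic ring. They also leave open how an unsubstituted cyclohexyl, an unsubstituted phenyl, a longer alkyl chain or an amine on this carbonyl carbon would read, and whether the same step would appear with a different group on the other side of the shared core.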